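A few compounds are considered here, and "the series" means these few. Any claim that something is new, unique, unknown or untested is made for them only; others in the source may bear on it.

Measured so far in a functional assay on HUVEC cells (Homo sapiens) for inhibition, with a stated time of 4 days; a higher number here means a weaker inhibitor, a lower number a stronger inhibitor:
- compound 1 `COc1ccc(C#N)cc1COc1ccc(Cl)c(C)c1`: 1500 nM
- compound 2 `COc1ccc(C(N)=O)cc1/C=C/c1ccc(Cl)cc1`: 87 nM
- compound 3 `COc1ccc(C(N)=O)cc1/C=C\c1ccc(Cl)cc1`: 2900 nM

Compound 2, at 87 nM, has the lowest number of the three and is the strongest inhibitor among them. Going by the values given here, the only measured step between closely matched compounds, a 33-fold higher number from compound 2 to compound 3 (1.52 log units; beyond the scatter), is large, and it goes with the fact that compounds 2 and 3 differ only in the configuration as drawn. Compound 4 `COc1ccc(C(N)=O)cc1/C=C/c1ccc(C(C)(C)C)cc1` keeps the E double bond of compound 2 and carries one structural change: tert-butyl in place of chloro on an aromatic carbon. The tert-butyl group replaces the chloro group on an aromatic carbon.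

Among the compounds with values here, no measured step touches that group, so the one step available bears on it only indirectly. It shows that numbers in this assay can shift widely within this series, but it gives no direction for this change. A rise is the likelier direction since compound 2 stands at 87 nM, the lowest number seen so far. That rise is expected to be moderate and smaller than the change in double-bond configuration produced. The expected change is a 3.4-fold higher number from compound 2 to compound 4 (0.54 log units; beyond the scatter). For compound 4 the estimated value is 300 nM, with an expected range from 60 nM to 1500 nM.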

Compound 4, half-maximal inhibitory concentration: 370 nM
Estimate against measurement, compound 4: 1.2-fold (0.09 log units) below; the range from low to high includes it.
By their numbers in this assay, from the lowest: compound 2; then compound 4; then compounds 1 and 3 (each within the scatter of the next).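

In this assay, going by these compounds alone, tert-butyl in place of chloro on an aromatic carbon, para to a large group, gives a 4.3-fold higher number from compound 2 to compound 4 (0.63 log units; beyond the scatter), the first measured evidence that the number responds to what is carried at this position. The response is limited: with 4 heavy atoms entering where 1 leaves, compound 4 still gives 370 nM, so this position accepts the larger group with only a modest rise in the number. The step is labelled modest, whereas the only other step between closely matched compounds is labelled large, and that large step remains tied to the double bond alone: the fact that compounds 2 and 3 differ only in the configuration as drawn

Within the data shown here, with only two groups compared at this position, the step does not show whether the rise follows the heavy-atom count or some other difference between chloro and tert-butyl. The compounds shown also do not tell how fluoro, methoxy or an amine on the same carbon would stand against these two groups, or whether the Z double bond would bring as large a step with tert-butyl as it does with chloro.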